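This account rests on a few compounds, and the source may have more. Where it says the series, first, only, none or still open, it means among the compounds named here.

Measured compounds:
compound 1 `O=C1CN(C2CCCC2)c2nc(Nc3ccc(N4CCCCC4)cn3)ncc2N1` — > 30000 nM
compound 2 `CC1CCN(c2ccc(Nc3ncc4c(n3)N(C3CCCC3)CC(=O)N4)nc2)CC1` — > 30000 nM
compound 3 `CN1C(=O)CN(C2CCCC2)c2nc(Nc3ccc(N4CCCCC4)cc3)ncc21` — 6100 nM

In a functional assay on HCT-116 cells (Homo sapiens) for inhibition, read by MTT assay, with a stated time of 48 h (on this read-out higher numbers stand for weaker inhibition and lower numbers for stronger inhibition), compound 1 gives only a limit, > 30000 nM. Compound 2 in this assay likewise gives only a limit, > 30000 nM. The change between them is methyl in place of hydrogen on a saturated ring carbon; the step that the two limits leave unreadable from compound 1 to compound 2 cannot be sized because both values sit at the limit of > 30000 nM in this assay, at which 2 of the 3 values shown sit.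

Compound 3 carries a different core; the difference between the cores of compound 1 and compound 3 is not broken down here. In this assay, going by the values given here, compound 3 gives 6100 nM, the only number among the three.

Compound 4 `CC1CCN(c2ccc(Nc3ncc4c(n3)N(C3CCCC3)CC(=O)N4C)cc2)CC1` has not been measured in this assay. It differs from compound 3 by methyl in place of hydrogen on a saturated ring carbon, the same change as from compound 1 to compound 2, at the same place. That earlier step is unreadable, so no sized effect carries over. The step from compound 3 to compound 4 is expected to be a 1.0-fold lower number from compound 3 to compound 4 (0.01 log units; within the scatter), close to no change, resting on compound 3 at 6100 nM and on the unreadable a step that the two limits leave unreadable from compound 1 to compound 2. Compound 4 is therefore estimated at 6000 nM in this assay, expected between 2000 nM and 20000 nM.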

Compound 4, half-maximal inhibitory concentration: 25300 nM
The estimate for compound 4 lay 4.2-fold (0.62 log units) below the measured number; the measured number lies above the stated range.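

In this assay, methyl in place of hydrogen on a saturated ring carbon, here piperidin-1-yl to 4-methylpiperidin-1-yl, gives a 4.1-fold higher number from compound 3 to compound 4 (0.62 log units; beyond the scatter) on the core of compound 3. This shows that the change is not neutral on that core, but one pair on one core sets no rule for the series. Whether the size of the step carries over to the core of compound 1 cannot be read, because compound 1 and compound 2 both give only a limit: the limit of > 30000 nM in this assay, at which 2 of the 4 values shown sit.

The compounds shown leave open whether an ethyl, a hydroxyl or a primary amine in place of that methyl would shift the number in this assay in the same direction on the core of compound 3. They also leave open how the methyl change behaves on a second core where both partners give a number and not a limit.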